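The compounds below may be only part of what the source reports. "The series", "measured", "known", "first", "only" and "open" are said of these compounds alone.

Compound 3 `O=C(CCCN1CCN(c2ccccc2Cl)CC1)Nc1ccc(Cl)cc1` gives 6010 nM in an assay on HEK293 cells for inhibition of Voltage-dependent T-type calcium channel subunit alpha-1G (Homo sapiens), read by patch clamp (on this read-out higher numbers stand for weaker inhibition and lower numbers for stronger inhibition), the largest number shown, though compound 2 `O=C(CCCN1CCN(c2ccc(F)cc2)CC1)Nc1ccc(Cl)cc1` at 3490 nM lies within the scatter of it; compound 1 `O=C(CCCCN1CCN(c2cccc(Cl)c2)CC1)Nc1ccccc1Cl` at 1910 nM sits beyond the scatter, lower. Among the measured compounds shown here, the one measured change at the amine nitrogen in the ring, a 1.7-fold higher number from compound 2 to compound 3 (0.24 log units; within the scatter), stayed within the scatter. Compound 4 `COc1cccc(N2CCN(CCCC(=O)Nc3ccc(Cl)cc3)CC2)c1` differs from compound 3 by 3-methoxyphenyl in place of 2-chlorophenyl on an amine nitrogen in a ring, the same place on the shared core. For the measured compounds named here, with only that step for guidance, no shift beyond the scatter in this assay is expected for compound 4. The estimate for compound 4 is 5000 nM, with a range from 1700 nM to 15000 nM, meaning an expected step of a 1.2-fold lower number from compound 3 to compound 4 (0.08 log units; within the scatter).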

Compound 4, half-maximal inhibitory concentration: 2780 nM
For compound 4 the middle estimate is 1.8-fold (0.25 log units) above the measured one; the measured number falls inside the stated range.
By their numbers in this assay, from the lowest: compounds 1, 4, 2 and 3 (each within the scatter of the next, the first and the last beyond it).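

This position now shows a step beyond the scatter, though a modest one: 3-methoxyphenyl in place of 2-chlorophenyl gives (a 2.2-fold lower number from compound 3 to compound 4 (0.33 log units; beyond the scatter)). The same group in place of 4-fluorophenyl gives (a 1.3-fold lower number from compound 2 to compound 4 (0.10 log units; within the scatter)), which stays within the scatter, so among these three groups only the pair of compound 3 and compound 4 is separated. No evidence on the cause of this step is at hand. Still open, going by these compounds, is how a hydroxyl or a dimethylamino group on this phenyl ring would read, and whether a benzyl group on the same nitrogen would keep these values.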